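The source may report more compounds than this note shows. Statements on the series, on what has been measured and on what is new or still open speak of the compounds shown alone.

Compound 1 `COc1ccc(C(=O)/C=C/c2ccc(-c3ccccc3)cc2)c2c1C=CC(C)(C)O2` gives > 10000 nM in a functional assay on HCT-116 cells (Homo sapiens) for antiproliferative activity, read by MTT assay, with a stated time of 24 h; a higher number here means a weaker inhibitor, a lower number a stronger inhibitor.
Compound 2 `COc1ccc(C(=O)/C=C/c2ccc3ccccc3n2)c2c1C=CC(C)(C)O2` gives 4530 nM in this assay.
Compound 3 `COc1ccc(C(=O)/C=C/c2ccc(OC)c(OC)c2OC)c2c1C=CC(C)(C)O2` gives > 10000 nM in this assay.

The series shares one core and varies the aryl group on the enone. For compound 1 the number is a limit of this assay, not a measured value. The same holds for compound 3, whose result is also a limit. Among the measured compounds shown here, compound 2 alone returns a number, so it is the only member of the three with a measured value; against the limits of compound 1 and compound 3 no ordered comparison can be drawn, because the limit of > 10000 nM in this assay, at which 2 of the 3 values shown sit, marks where two of the three results sit.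

Compound 4 `COc1ccc(C(=O)/C=C/c2ccc(Cl)cc2)c2c1C=CC(C)(C)O2` carries the change (chloro in place of phenyl on an aromatic carbon). For the measured compounds named here, no measured pair in this set shares that change, so the size of the step cannot be read from the data. The author expects the step from compound 1 to compound 4 an at least 1.2-fold lower number from compound 1 to compound 4 (0.09 log units; that floor lies within the scatter) to be modest, with compound 4 staying weak, and estimates compound 4 at 8000 nM (range 2500 nM to 20000 nM).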

Compound 4, half-maximal inhibitory concentration: > 10000 nM
Compound 4 was reported as a limit (the forecaster's own chance of this, stated with the estimate: 45%); middle value at least 1.2-fold (0.09 log units) away from the limit.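

In this assay, among the compounds shown here, compound 4 gives > 10000 nM, a limit, so no step from compound 1, itself a limit, to compound 4 can be read: the limit of > 10000 nM in this assay, at which 3 of the 4 values shown sit. The compounds shown leave open whether chloro in place of phenyl changes antiproliferative activity at all.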